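A few compounds are considered here, and "the series" means these few. Any claim that something is new, unique, unknown or untested is made for them only; others in the source may bear on it.

Measured so far:
- compound 1, `CCNc1nc(C)c(-c2nc3ccccc3s2)c(N[C@@H]2C[C@H](CO)[C@@H](O)[C@H]2O)n1`: 2580 ng.h/mL
- compound 2, `Cc1nc(NC(C)C)nc(N[C@@H]2C[C@H](CO)[C@@H](O)[C@H]2O)c1-c1nc2ccccc2s1`: 8420 ng.h/mL
- compound 3, `Cc1nc(NCc2ccsc2)nc(N[C@@H]2C[C@H](CO)[C@@H](O)[C@H]2O)c1-c1nc2ccccc2s1`: 96.7 ng.h/mL

These three compounds share one core and differ only in the group carried on a nitrogen on an aromatic ring. In an ADME assay on the whole organism (plasma) for pharmacokinetics, with Rattus norvegicus as the target, with a stated time of 6 h, at a dose of 10 mg/kg by the oral route (a higher number here means more compound in the circulation at the dose given, a lower number less compound in the circulation), compound 1 stands second highest of the three: compound 2 lies nearest to it, with a 3.3-fold higher number from compound 1 to compound 2 (0.51 log units; beyond the scatter), and compound 3 lies furthest, with a 27-fold lower number from compound 1 to compound 3 (1.43 log units; beyond the scatter).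

The unmeasured compound 4, `Cc1nc(NCc2cccnc2)nc(N[C@@H]2C[C@H](CO)[C@@H](O)[C@H]2O)c1-c1nc2ccccc2s1`, arises from compound 1 by the change (pyridin-3-yl in place of methyl on a saturated chain carbon bound to a nitrogen on an aromatic ring). Among the measured compounds shown here, the step that bears most on this change is the one from compound 1 to compound 3, where a different aromatic ring took the same place and gave a 27-fold lower number from compound 1 to compound 3 (1.43 log units; beyond the scatter). The step from compound 2 to compound 3, an 87-fold lower number from compound 2 to compound 3 (1.94 log units; beyond the scatter), points the same way: in both measured cases the aromatic ring on the saturated chain carbon went with a much lower number in this assay. Whether a pyridin-3-yl ring behaves like a thiophen-3-yl ring there is not known from these compounds, so the size of the step is uncertain.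

The number for compound 4 is therefore expected to be well below that of compound 1, with an estimated step of a 13-fold lower number from compound 1 to compound 4 (1.11 log units; beyond the scatter). For compound 4 the estimate is 200 ng.h/mL, with a range from 40 ng.h/mL to 1000 ng.h/mL.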

Compound 4, area under the concentration-time curve: 9.57 ng.h/mL
Estimate against measurement, compound 4: 21-fold (1.32 log units) above; the whole stated range lies above it.
By their numbers in this assay, from the lowest: compound 4; then compound 3; then compound 1; then compound 2.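

In this assay, the kind of aromatic ring on this saturated chain carbon matters as well as its presence: pyridin-3-yl in place of thiophen-3-yl gives a 10-fold lower number from compound 3 to compound 4 (1.00 log units; beyond the scatter). Among the compounds shown here, the low numbers are therefore not confined to the thiophen-3-yl group, and the pyridin-3-yl ring takes the compound further down than the earlier steps did, with a 270-fold lower number from compound 1 to compound 4 (2.43 log units; beyond the scatter) and an 880-fold lower number from compound 2 to compound 4 (2.94 log units; beyond the scatter). Both compounds with an aromatic ring in this place now sit below the two with simple alkyl groups, with no compound shown going against that order, but nothing available here explains why the pyridin-3-yl ring gives the lowest number of the four.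

Still open, on these data alone, is how a plain phenyl ring on the same carbon would compare, and whether it would fall closer to compound 3 or to compound 4. A saturated ring such as cyclohexyl, or a longer chain such as butyl, would show whether the low numbers go with aromatic rings in particular or with any larger group in this place.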